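A few compounds are considered here, and "the series" means these few. Any claim that something is new, unique, unknown or untested is made for them only; others in the source may bear on it.

Measured so far:
compound 1, `O=[N+]([O-])c1ccc(COc2ccc(Nc3ncnc4cc5c(cc34)OCCOCCO5)cc2)cc1`, 55200 nM
compound 2, `c1ccc(COc2ccc(Nc3ncnc4cc5c(cc34)OCCOCCO5)cc2)cc1`, 39300 nM
compound 3, `O=[N+]([O-])c1ccc(COc2cccc(Nc3ncnc4cc5c(cc34)OCCOCCO5)c2)cc1`, 36600 nM

All three were tested in a functional assay on SH-SY5Y cells (Homo sapiens) for antiproliferative activity, read by MTT assay, with a stated time of 72 h; a higher number here means a weaker inhibitor, a lower number a stronger inhibitor. Compound 1 and compound 2 share one core and differ in a single place: hydrogen in place of nitro on an aromatic carbon. The step this change made is a 1.4-fold lower number from compound 1 to compound 2 (0.15 log units; within the scatter), so the two values sit within the usual scatter of each other and no direction can be read from them. Compound 3 is built from the same atoms as compound 1, joined differently; the difference between the two cores is not broken down here, and the two values of compound 1 and compound 3 lie within the scatter of each other.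

Compound 4, `c1ccc(COc2cccc(Nc3ncnc4cc5c(cc34)OCCOCCO5)c2)cc1`, has not yet been measured in this assay. It stands to compound 3 as compound 2 stands to compound 1: the change is hydrogen in place of nitro on an aromatic carbon, and since the surroundings of the place are described in the same words in both cases, this is the same change. Among the measured compounds shown here, the only guide to its effect is the earlier step, which was within the scatter. Compound 4 is therefore expected to give about 30000 nM, because compound 3 gives 36600 nM and the same change before barely moved the number. The expected step is a 1.2-fold lower number from compound 3 to compound 4 (0.09 log units; within the scatter). The range expected for compound 4 runs from 15000 nM to 70000 nM.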

Compound 4, half-maximal inhibitory concentration: 68400 nM
Compound 4: the middle estimate sits 2.3-fold (0.36 log units) below what was measured; the measured number falls inside the stated range.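

In this assay, the step on the second core is a 1.9-fold higher number from compound 3 to compound 4 (0.27 log units; within the scatter), and like the earlier step it stays within the usual scatter of repeated measurements. On paper the two steps point in opposite directions, but the gap between them is no larger than the scatter of two such steps allows, so the two cores cannot be said to respond differently: the same change on two cores in this assay, a 1.4-fold lower number (0.15 log units; within the scatter) from compound 1 to compound 2 and a 1.9-fold higher number (0.27 log units; within the scatter) from compound 3 to compound 4, 2.6-fold (0.42 log units) apart, within the scatter of two such steps This shows that going from 4-nitrobenzyl to benzyl left the number within the scatter on both cores, a modest sign that the change carries from one core to the other as a small step; it does not show that the change truly raises or lowers the number on either core, or that the two cores respond identically, and two pairs alone are too few to settle either point.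

The compounds shown carry only nitro or hydrogen at this place on the ring, so it stays open whether a different group there, such as an amine, a carboxylic acid or a methoxy group, would move the number beyond the scatter. From the compounds shown here alone, it also stays open whether such a group would behave the same way on both cores.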